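Chloro for Methyl on the Aryl Ketone

The source may hold more compounds than are shown below. What is called first, only, known or untested is meant among the compounds shown, and "the series" means these compounds.

Compound 1 `COc1ccc(-c2cc(/C=C/C(=O)c3ccc(C)cc3)nc3cc(-c4ccccc4)nn23)cc1OC`: 17200 nM
Compound 2 `COc1cc(-c2cc(/C=C/C(=O)c3ccc(C)cc3)nc3cc(-c4ccccc4)nn23)cc(OC)c1OC`: 19400 nM
Compound 3 `COc1ccc(C(=O)/C=C/c2cc(-c3ccc(OC)cc3)n3nc(-c4ccccc4)cc3n2)cc1`: 2900 nM

In a functional assay on A549 cells (Homo sapiens) for antiproliferative activity, read by MTT assay, with a stated time of 24 h (on this read-out lower numbers stand for stronger inhibition and higher numbers for weaker inhibition), compound 2 gives 19400 nM, the highest of the three numbers. Compound 1 lies nearest, the step being a 1.1-fold higher number from compound 1 to compound 2 (0.05 log units; within the scatter), within the scatter. Compound 3 lies furthest with 2900 nM, a gap beyond the scatter.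

Compound 4 `COc1cc(-c2cc(/C=C/C(=O)c3ccc(Cl)cc3)nc3cc(-c4ccccc4)nn23)cc(OC)c1OC` differs from compound 2 by chloro in place of methyl on an aromatic carbon. Among the measured compounds shown here, no measured step touches this change: the only measured step, a 1.1-fold higher number from compound 1 to compound 2 (0.05 log units; within the scatter), adds a methoxy on a different ring and is itself within the scatter. With nothing to point either way, no step beyond the scatter is expected in this assay. Compound 4 is therefore expected to give 19000 nM, between 8000 nM and 45000 nM. The expected step is a 1.0-fold lower number from compound 2 to compound 4 (0.01 log units; within the scatter).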

Compound 4, half-maximal inhibitory concentration: 15500 nM
Compound 4: the middle estimate sits 1.2-fold (0.09 log units) above what was measured; low and high end bracket the measured number.
By their numbers in this assay, from the lowest: compound 3; then compounds 4, 1 and 2 (each within the scatter of the next).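

In this assay, replacing the methyl of the 4-methylphenyl ketone with chloro gives a 1.3-fold lower number from compound 2 to compound 4 (0.10 log units; within the scatter) and so stays within the scatter. This is the only step shown on this ring, as the earlier step changed a methoxy on a different ring, and it shows that these two groups read alike here. No outside measurement bears on this result.

Among the compounds shown here, only two small groups have been compared at this position. An amine or a carboxylic acid in their place might still move the number beyond the scatter.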